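This account rests on a few compounds, and the source may have more. Where it says the series, first, only, none or still open, it means among the compounds named here.

For the measured compounds named here, in a functional assay on HL-60 cells (Homo sapiens) for antiproliferative activity, with a stated time of 72 h (a lower number here means a stronger inhibitor of growth, a higher number a weaker inhibitor of growth), compound 1 `C=C(CCCC)C(=O)c1ccc(OCC(=O)OC)c(C)c1C` gives 8600 nM as the only true number in this small set. Compound 2 `C=C(CC)C(=O)c1ccc(OCC(=O)O)cc1C` has no such number, since compound 2 reads > 60000 nM and that reading is a limit. Compound 3 `C=C(CC)C(=O)c1ccc(OCC(=O)O)cc1Br` is no different, since compound 3 reads > 60000 nM and that too is a limit.

Compound 4 `C=C(CC)C(=O)c1ccc(OC(C)C(=O)O)cc1C` has not yet been measured. It carries methyl in place of hydrogen on a saturated chain carbon bound to a carbonyl carbon and an oxygen on an aromatic ring so carboxymethoxy becomes 1-carboxyethoxy.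

Going by the values given here, the one measured step, a step that the two limits leave unreadable from compound 2 to compound 3 with bromo in place of methyl on an aromatic carbon, lies elsewhere on the structure and has no readable size. The closest guide is therefore the limit of > 60000 nM in this assay, at which 2 of the 3 values shown sit, and it gives a limit rather than a number. Among the compounds with values here, no measured step shows what this new methyl does, so no clear shift in either direction is expected in this assay for now. The expected change is a step that the limit leaves unreadable from compound 2 to compound 4 and this is only a rough estimate. For compound 4 the estimated value is 70000 nM with an expected range from 30000 nM to 120000 nM in this test.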

Compound 4, concentration for 50% growth inhibition: > 60000 nM
Compound 4: no number, only a limit (the forecaster's own chance of this, stated with the estimate: 85%); the middle value does not contradict the limit.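

Compound 2 and compound 4 both give only a limit in this assay, so the step between them cannot be read. The set as a whole mostly sits at one reading: the limit of > 60000 nM in this assay, at which 3 of the 4 values shown sit.

The compounds shown leave open whether 1-carboxyethoxy in place of carboxymethoxy changes growth inhibition at all in this assay.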